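The source may hold more compounds than are shown below. What is called first, only, known or untested is meant among the compounds shown, and "the series" means these compounds.

Measured compounds:
compound 1, `N=c1oc2ccc(Br)cc2cc1C(=O)NC1CCCCC1`: 5%
compound 2, `O=C(O)CNC(=O)c1cc2ccccc2oc1=O`: 1%
compound 3, `O=C(NC1CCCC1)c1cc2ccccc2oc1=O`: 16%

In an assay on CHO cells for displacement of a labelled ligand from adenosine receptor A1 (Homo sapiens), read by scintillation counting, with a stated time of 60 min, tested at 10 uM (a higher number here means more inhibition at the concentration tested (going by the name of the read-out), a lower number less inhibition), compound 1 gives 5%, the second highest of the three numbers. Its nearest neighbour is compound 2 with 1%, a gap that lies within the scatter, so no order between the two can be claimed. Compound 3, with 16%, stands higher than compound 1 by a margin beyond the scatter.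

Compound 4, `N=c1oc2ccc(Br)cc2cc1C(=O)NCCCO`, has not yet been measured in this assay. It differs from compound 1 in one place: 3-hydroxypropyl in place of cyclohexyl on an amide-type nitrogen.

Within the data shown here, only one measured step offers guidance. Going from compound 2 to compound 3, a ring replaced an open chain on the amide-type nitrogen and gave a number 15 percentage points higher from compound 2 to compound 3 (beyond the scatter). The change from compound 1 to compound 4 runs the other way, a ring leaving and an open chain entering on the same kind of nitrogen, so a modest move downward would be the natural expectation; but compound 1 already sits close to zero, leaving little room to fall. A step of a number 3 percentage points lower from compound 1 to compound 4 (within the scatter) is therefore expected, small enough to stay within the scatter. For compound 4 the estimate is 2%, with a range from -8% to 12%.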

Compound 4, a percentage reported as inhibition, at one concentration (the size of the read-out at that concentration, not a potency): 32%
Beside the measured number, compound 4's estimate is 30 percentage points below it; the whole stated range lies below it.
By their numbers in this assay, from the lowest: compounds 2 and 1 (each within the scatter of the next); then compound 3; then compound 4.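

In this assay, the change from cyclohexyl to 3-hydroxypropyl on the amide-type nitrogen gives a number 27 percentage points higher from compound 1 to compound 4 (beyond the scatter), so this position on the core of compound 1 does respond to what is attached there. The earlier step, a number 15 percentage points higher from compound 2 to compound 3 (beyond the scatter), put a ring in place of an open chain and raised the number, whereas here an open chain in place of a ring does so; taken together, the two steps show that a ring on this nitrogen does not by itself give the higher number, and that the open chain matters as well as the presence or absence of a ring. No measurement shown here explains why the number rises with this change.

The compounds shown leave open whether the rise comes from the hydroxyl or from the chain itself, which a plain propyl group would help to separate, and whether a longer chain or an amine in place of the hydroxyl would go further. They also leave open whether the same change would give a similar step on the core of compound 3.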